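From 4-fluorophenyl to 2-fluorophenyl

The source may hold more compounds than are shown below. What is called first, only, known or untested is meant among the compounds shown, and "the series" means these compounds.

Among the measured compounds shown here, in a functional assay on OCI-My4 cells (Homo sapiens) for antiproliferative activity, read by MTT assay, with a stated time of 72 h (a higher number here means a weaker inhibitor, a lower number a stronger inhibitor), compound 1 (`C[C@H](NC(=O)/C(C#N)=C/c1cccc(Br)n1)c1ccc(Br)cc1`) gives 2000 nM as the only number so far. Compound 2 (`C[C@H](NC(=O)/C(C#N)=C/c1cccc(Br)n1)c1ccc(F)cc1`) stands at "not determined" (no result reported), so it offers no starting value. Compound 3 (`C[C@H](NC(=O)/C(C#N)=C/c1cccc(Br)n1)c1ccccc1F`) carries 2-fluorophenyl in place of 4-fluorophenyl on a saturated chain carbon bound to an amide-type nitrogen and a saturated chain carbon with the same atoms joined differently. For the measured compounds named here, no measured step informs this change. In this assay, going by the values given here, the level of compound 1 (2000 nM) remains the only guide, and no clear shift from it is expected in either direction. Compound 3 is estimated at 2500 nM with 800 nM as the expected lower end and 8000 nM as the upper end.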

Compound 3, half-maximal inhibitory concentration: 2400 nM
The estimate for compound 3 lay 1.0-fold (0.02 log units) above the measured number; low and high end bracket the measured number.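

In this assay replacing 4-bromophenyl with 2-fluorophenyl on a saturated chain carbon bound to an amide-type nitrogen and a saturated chain carbon gives a 1.2-fold higher number from compound 1 to compound 3 (0.08 log units; within the scatter) and thus no shift that can be told from scatter. The step from 4-fluorophenyl to 2-fluorophenyl cannot be read: compound 2 has no reported result. No measurement at hand explains the outcome at this position. Still open, on these data alone, is whether an aminophenyl or carboxyphenyl group here would move the number beyond the scatter.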